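Removing a propyl from a weak pyrazolylamine inhibitor

This account rests on a few compounds, and the source may have more. Where it says the series, first, only, none or still open, it means among the compounds named here.

Compound 1 `CCCc1nc(C)c2ccnc(Nc3cc[nH]n3)n12` is the starting point of this comparison. Among the measured compounds shown here, in a functional assay for inhibition, with Homo sapiens as the target (on this read-out lower numbers stand for stronger inhibition and higher numbers for weaker inhibition), compound 1 gives 25000 nM, the only finished number among the three measured compounds. Compound 2 `CCCc1cnc(Nc2cc[nH]n2)n2c(CCC)nc(C)c12` is the next. For compound 2 the result in this assay is a limit of the assay rather than a number, > 48000 nM. Compound 3 `CSc1nncc2c(C)nc(C(C)C)n12` is the third. For compound 3 the result in this assay is likewise a limit, > 48000 nM. Both sit at the limit of > 48000 nM in this assay, at which 2 of the 3 values shown sit.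

For the measured compounds named here, the one measured step that differs in a single place runs from compound 1 to compound 2, where a propyl takes the place of a hydrogen on an aromatic carbon; it gives an at least 1.9-fold higher number from compound 1 to compound 2 (0.28 log units; that floor lies within the scatter).

Compound 4 `Cc1ncn2c(Nc3cc[nH]n3)nccc12` has not been measured. It differs from compound 1 by hydrogen in place of propyl on an aromatic carbon. This is the opposite kind of change to the measured step, though at a different aromatic carbon, and that step itself stayed within the scatter, so no step beyond the scatter is expected in this assay. Compound 4 is therefore expected at about 22000 nM, between 8000 nM and 60000 nM, an expected step of a 1.1-fold lower number from compound 1 to compound 4 (0.06 log units; within the scatter).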

Compound 4, half-maximal inhibitory concentration: 57000 nM
Compound 4: the middle estimate sits 2.6-fold (0.41 log units) below what was measured; the range from low to high includes it.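

Taking the propyl away from the aromatic carbon of the five-membered aromatic ring, between two ring nitrogen atoms, does not leave the result in this assay unchanged (a 2.3-fold higher number from compound 1 to compound 4 (0.36 log units; beyond the scatter)). This is the first step among the compounds shown that lies beyond the scatter, so the propyl at this place does count, if only modestly, and within this pair its presence goes with the lower number and so with the stronger inhibition. The earlier propyl step, at a different aromatic carbon, ended in a limit and offered only a floor within the scatter, so it could not show that a propyl made any difference on this core.

As far as these compounds go, whether a shorter chain such as ethyl, a longer chain such as butyl, or an amine on this same carbon would lower the number further stays open. The weak end of the comparison also remains unresolved, with compound 2 and compound 3 each standing at a limit of the assay rather than at a number: the limit of > 48000 nM in this assay, at which 2 of the 4 values shown sit.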